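This account rests on a few compounds, and the source may have more. Where it says the series, first, only, none or still open, it means among the compounds named here.

Going by the values given here, compound 3 `CC(C)[C@H](NC(=O)COc1cccc2ccccc12)C(=O)N[C@@H](CC(=O)O)C(=O)CSc1nc(-c2ccccc2)no1` is the only member of this set to return a number in a functional assay on Jurkat cells (Homo sapiens) for inhibition (on this read-out higher numbers stand for weaker inhibition and lower numbers for stronger inhibition), where compound 3 gives 102000 nM. Compound 1 `CC(C)[C@H](NC(=O)COc1cccc2ccccc12)C(=O)N[C@@H](CC(=O)O)C(=O)CSc1nccn1C` differs from it only in the group on the sulfur, and in this assay compound 1 returns a limit, > 200000 nM. Compound 2 `CC(C)[C@H](NC(=O)COc1cccc2ccccc12)C(=O)N[C@@H](CC(=O)O)C(=O)CSc1nc(-c2ccccc2)c(-c2ccccc2)[nH]1` likewise returns a limit in this assay, > 200000 nM. Among the compounds with values here, the single step that can be read, an at least 1.9-fold lower number from compound 1 to compound 3 (0.29 log units; that floor lies within the scatter), rests on the limit of > 200000 nM in this assay, at which 2 of the 3 values shown sit, and so gives only a floor, which itself lies within the scatter. Compound 4 `CC(C)[C@H](NC(=O)COc1cccc2ccccc12)C(=O)N[C@@H](CC(=O)O)C(=O)CSc1nc2ccccc2[nH]1` carries a further change at the same place, (1H-benzimidazol-2-yl in place of 3-phenyl-1,2,4-oxadiazol-5-yl on a sulfur). Within the data shown here, no measured step tells how this exchange of ring acts, and the one step that is known is too small to point in either direction, so the expectation is for no shift beyond the scatter. Compound 4 is therefore estimated to give 100000 nM in this assay, within 30000 nM to 300000 nM, which corresponds to an expected step of a 1.0-fold lower number from compound 3 to compound 4 (0.01 log units; within the scatter).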

Compound 4, half-maximal inhibitory concentration: > 200000 nM
Compound 4 gave a limit, no number; the forecaster's own chance of this, stated with the estimate: 45%; middle value at least 2.0-fold (0.30 log units) from the limit.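

In this assay, placing 1H-benzimidazol-2-yl on the sulfur gives an at least 1.9-fold higher number from compound 3 to compound 4 (0.29 log units; that floor lies within the scatter), so this exchange yields only a floor and no measured size. Compound 4 joins compound 1 and compound 2 at a limit, which leaves 3-phenyl-1,2,4-oxadiazol-5-yl as the only group shown at this place with a number, and the steps between limits cannot be read. Three different groups on the sulfur now end at the same limit, so the set gives no ranking at this place: the limit of > 200000 nM in this assay, at which 3 of the 4 values shown sit.

On these data alone, how a plain phenyl or a pyridin-2-yl on the sulfur would read in this assay stays open. Also open, as far as these compounds go, is whether any group here can give a number clearly lower than that of compound 3, or whether a change elsewhere, such as an ester in place of the carboxylic acid, would be needed.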